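The source may hold more compounds than are shown below. What is called first, only, known or untested is meant among the compounds shown, and "the series" means these compounds.

Measured compounds in the series:

- compound 1 `COc1ccc(/C=C/C(=O)NNC(=O)c2ccc3c(c2)OCCO3)cc1`: 930 nM
- compound 2 `O=C(/C=C/c1ccc(Br)cc1)NNC(=O)c1ccc2c(c1)OCCO2`: 2330 nM
- compound 3 `O=C(/C=C/c1cccc([N+](=O)[O-])c1)NNC(=O)c1ccc2c(c1)OCCO2`: 1560 nM

In a functional assay on cells (Cancer cell lines, Homo sapiens) for inhibition, read by MTT assay, with a stated time of 48 h (a higher number here means a weaker inhibitor, a lower number a stronger inhibitor), the three measured compounds lie close together. Compound 3 stands second highest of the three numbers; a 1.5-fold lower number from compound 2 to compound 3 (0.17 log units; within the scatter) and a 1.7-fold higher number from compound 1 to compound 3 (0.22 log units; within the scatter) both fall within the scatter, so no order among these pairs can be read. Within the data shown here, the only step beyond the scatter is a 2.5-fold higher number from compound 1 to compound 2 (0.40 log units; beyond the scatter), a modest rise when a halogen replaces methoxy on the aromatic ring.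

Compound 4 `O=C(/C=C/c1cccc(Cl)c1)NNC(=O)c1ccc2c(c1)OCCO2` differs from compound 3 by chloro in place of nitro on an aromatic carbon. Among the measured compounds shown here, no measured step exchanges nitro for a halogen, so the case rests on indirect evidence: the one halogen-bearing compound, compound 2, gives the highest number of the three, and compound 3 with nitro is within the scatter of it. Compound 4 is therefore expected to land near compound 2, with a 1.3-fold higher number from compound 3 to compound 4 (0.11 log units; within the scatter) estimated to stay within the scatter, if anything leaning toward a slightly higher number. For compound 4 the estimate is 2000 nM, with a range from 900 nM to 4500 nM.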

Compound 4, half-maximal inhibitory concentration: 3560 nM
Compound 4: the middle estimate sits 1.8-fold (0.25 log units) below what was measured, within the range that was stated.
By their numbers in this assay, from the lowest: compounds 1, 3, 2 and 4 (each within the scatter of the next, the first and the last beyond it).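

In this assay, among these compounds, this is the first direct exchange at this aromatic carbon, and it moves the number beyond the scatter: a 2.3-fold higher number from compound 3 to compound 4 (0.36 log units; beyond the scatter). So nitro and chloro at this position can be told apart, although compound 3 could not be separated from either compound 1 or compound 2. The two halogen-bearing compounds cannot be separated from each other, a 1.5-fold higher number from compound 2 to compound 4 (0.18 log units; within the scatter), and the widest step in the series is now a 3.8-fold higher number from compound 1 to compound 4 (0.58 log units; beyond the scatter). No measurement in hand bears on what lies behind these steps.

On these data alone, compound 2 and compound 4 differ in both the halogen and its place on the ring, so the contribution of each remains open. Also open, as far as these compounds go, is how an amine or a carboxylic acid on this same aromatic carbon would compare with chloro and nitro.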